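This account rests on a few compounds, and the source may have more. Where it says the series, first, only, none or still open, it means among the compounds named here.

Two analogues of one core have been run in an ADME assay on cells (Splenocyte, Mus musculus, strain BALB/c) for cytotoxicity, read by CCK-8 assay, with a stated time of 48 h; a higher number here means that more compound is tolerated, a lower number that less compound is tolerated. Compound 1 `COc1ccccc1-c1nc(Cc2c[nH]c3ccccc23)no1` gives 42200 nM there. Compound 2 `COc1cccc(-c2nc(Cc3c[nH]c4ccccc34)no2)c1` gives 18400 nM in this assay, the lowest of the two numbers, and the gap to compound 1 lies beyond the usual scatter. Compound 3 `COc1ccc(OC)c(-c2nc(Cc3c[nH]c4ccccc34)no2)c1` is not yet measured; it differs from compound 2 by methoxy in place of hydrogen on an aromatic carbon. Within the data shown here, no measured pair tests this change, so compound 3 is expected to stay close to compound 2 in this assay. The step of a 1.2-fold higher number from compound 2 to compound 3 (0.08 log units; within the scatter) is expected to fall within the scatter. Compound 3 is estimated at 22000 nM, with a range from 8000 nM to 55000 nM.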

Compound 3, half-maximal cytotoxic concentration: > 50000 nM
Compound 3: only a limit was reported (the forecaster's own chance of this, stated with the estimate: 10%); at least 2.2-fold (0.35 log units) between middle value and limit.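

In this assay, methoxy in place of hydrogen on an aromatic carbon, ortho to a large group and para to a methoxy group, gives an at least 2.7-fold higher number from compound 2 to compound 3 (0.43 log units; beyond the scatter), so a change at this position can shift the read-out towards more compound tolerated. The other step, an at least 1.1-fold higher number from compound 1 to compound 3 (0.07 log units; that floor lies within the scatter), does not separate compound 3 from compound 1. Compound 3 gives a limit, not a number: the limit of > 50000 nM in this assay, at which 1 of the 3 values shown sits.

On these data alone, how far compound 3 lies past this limit remains open. Also open, as far as these compounds go, is whether an amine or a carboxylic acid at this position gives a similar shift.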